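Swapping the ring-nitrogen substituent from phenyl to methoxybenzyl

The source may hold more compounds than are shown below. What is called first, only, known or untested is meant among the compounds shown, and "the series" means these compounds.

Compound 3 `Cn1c(-c2ccc(NC(=O)CN3CCN(c4ccccc4)CC3)cc2)nc(-c2ccccc2)c1-c1ccccc1` sits second highest of the three measured compounds in a functional assay on HT-29 cells (Homo sapiens) for cytotoxicity, read by MTT assay, with a stated time of 24 h, tested at 16 ug/mL (a lower number here means a weaker effect, a higher number a stronger effect of the compound at the concentration tested), where compound 3 gives 55.4%. Compound 1 `Cn1nnnc1SCC(=O)Nc1ccc(-c2nc(-c3ccccc3)c(-c3ccccc3)n2C)cc1` gives 72.5%, and compound 2 `CN(C)/C=C/N1CCN(CC(=O)Nc2ccc(-c3nc(-c4ccccc4)c(-c4ccccc4)n3C)cc2)CC1` gives 28.2%. Compound 4 `COc1ccc(CN2CCN(CC(=O)Nc3ccc(-c4nc(-c5ccccc5)c(-c5ccccc5)n4C)cc3)CC2)cc1` carries 4-methoxybenzyl in place of phenyl on an amine nitrogen in a ring. The step that bears most on this change is the one at the same ring nitrogen, a number 27.2 percentage points higher from compound 2 to compound 3 (beyond the scatter), which shows that the group on that nitrogen can move the read-out a lot. Among the compounds with values here, no measured step compares phenyl with a benzyl-type group, so the direction is uncertain, though a change beyond the scatter seems likely. Compound 4 is therefore expected to give 48%, within 28% to 68%, a step of a number 7.4 percentage points lower from compound 3 to compound 4 (within the scatter).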

Compound 4, a percentage reported as activity, at one concentration (the size of the read-out at that concentration, not a potency): 21.8%
For compound 4 the middle estimate is 26.2 percentage points above the measured one; the whole stated range lies above it.
By their numbers in this assay, from the lowest: compounds 4 and 2 (each within the scatter of the next); then compound 3; then compound 1.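

In this assay the step to 4-methoxybenzyl on the ring nitrogen is a number 33.6 percentage points lower from compound 3 to compound 4 (beyond the scatter), so keeping an aromatic ring of carbon only on this nitrogen does not keep the read-out near that of phenyl. The other new step is a number 6.4 percentage points lower from compound 2 to compound 4 (within the scatter), so this assay does not separate 4-methoxybenzyl from 2-(dimethylamino)ethenyl, while phenyl stands above both. Nothing measured here gives a reason for these differences. From the compounds shown here alone, what stays open is whether the step follows the methoxy group or the extra carbon that links the ring to the nitrogen; unsubstituted benzyl at this nitrogen would bear on that.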